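Three Limits and One Untested Chain Variant

The source may hold more compounds than are shown below. What is called first, only, known or untested is meant among the compounds shown, and "the series" means these compounds.

Measured so far:
- compound 1, `CCC/N=C(/NC#N)NCCCCn1nc(-c2ccccc2)ccc1=O`, gives > 100 mg/kg in a functional assay on the whole organism (stomach) with Rattus norvegicus as the target; a higher number here means that more compound is needed for the effect, a lower number that less compound is needed; this value is a limit of the assay.
- compound 2, `C/N=C(/NC#N)NCCCCCn1nc(-c2ccccc2)c(C)cc1=O`, gives > 100 mg/kg in this assay; this too is a limit.
- compound 3, `C/N=C(/NC#N)NCCCCCCn1nc(-c2ccccc2)ccc1=O`, gives > 100 mg/kg in this assay; again a limit.

Going by the values given here, none of the three compounds has a numerical result: each sits at the same limit, (the limit of > 100 mg/kg in this assay, at which 3 of the 3 values shown sit), so no step between any pair can be measured and no ranking among them is possible. Compound 3 therefore stands at that limit together with the other two values, with nothing to set it apart.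

Compound 4, `CCC/N=C(/NC#N)NCCCCCn1nc(-c2ccccc2)ccc1=O`, is the untested member. Compared with compound 3 the change is a group of 9 heavy atoms (5 carbon, 4 nitrogen; no ring) in place of a group of 8 heavy atoms (4 carbon, 4 nitrogen; no ring), on a saturated chain carbon, five bonds along the chain from an aromatic nitrogen. Among the compounds with values here, the data give no measured step that would show what such a change does, and nothing among compounds 1, 2 or 3 shows any effect in this assay at all.

On that basis no step beyond the usual scatter is expected in this assay, and the expected step that the limit leaves unreadable from compound 3 to compound 4 is essentially flat. Compound 4 is thus estimated at 150 mg/kg, within a range of 50 mg/kg to 500 mg/kg, with a strong chance that the assay again returns only a limit.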

Compound 4, dose for half-maximal effect: > 100 mg/kg
Compound 4: only a limit was reported (the forecaster's own chance of this, stated with the estimate: 75%); the middle value does not contradict the limit.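

In this assay compound 4 gives > 100 mg/kg, which is again a limit of the assay and not a number. No step from compound 3 to compound 4 can be read, and the same limit holds across the series: the limit of > 100 mg/kg in this assay, at which 4 of the 4 values shown sit.

The compounds shown leave open what dose of any of them would give the effect, and whether changing the chain makes any difference in this assay.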